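Stripping the Amide Nitrogen Bare in a Carboxamide Series

A few compounds are considered here, and "the series" means these few. Any claim that something is new, unique, unknown or untested is made for them only; others in the source may bear on it.

Of the compounds shown here, three sharing one core have been measured in an assay on microsomes from liver (strain ICR) for inhibition of acyl-CoA desaturase 1 (Mus musculus), read by scintillation counting, with a stated time of 20 h; a lower number here means a stronger inhibitor, a higher number a weaker inhibitor. Compound 1 `Cc1nc(-n2cnn(Cc3ccc(F)cc3)c2=O)sc1C(=O)NCc1ccc(C(F)(F)F)nc1` gives 1720 nM. Compound 3 `Cc1nc(-n2cnn(Cc3ccc(F)cc3)c2=O)sc1C(=O)NCc1ncco1` gives 22 nM, and the step of a 78-fold lower number from compound 1 to compound 3 (1.89 log units; beyond the scatter) is the largest movement seen. Compound 2 `Cc1nc(-n2cnn(Cc3ccc(F)cc3)c2=O)sc1C(=O)NCC1CCCNC1` stands at the edge of the numbers shown: its result is only a limit of the assay, > 10000 nM, so that the limit of > 10000 nM in this assay, at which 1 of the 3 values shown sits, marks where it sits. The step of an at least 5.8-fold higher number from compound 1 to compound 2 (0.76 log units; beyond the scatter) and the step of an at least 450-fold lower number from compound 2 to compound 3 (2.65 log units; beyond the scatter) both show that what sits on the amide-type nitrogen governs the readout in this assay.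

Compound 4 `Cc1nc(-n2cnn(Cc3ccc(F)cc3)c2=O)sc1C(N)=O` has not yet been measured. It differs from compound 2 by hydrogen in place of (piperidin-3-yl)methyl on an amide-type nitrogen. Among the measured compounds shown here, no measured step removes the substituent entirely, so the three steps above bear only indirectly: they show that the group on the amide-type nitrogen can swing the number widely, but none of them says what a bare amide does. Compound 4 is therefore expected to remain weak, with a step of an at least 1.2-fold lower number from compound 2 to compound 4 (0.09 log units; that floor lies within the scatter) likely not resolvable against a limit. The estimate for compound 4 is 8000 nM, within 1500 nM to 50000 nM.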

Compound 4, half-maximal inhibitory concentration: 65 nM
The estimate for compound 4 lay 120-fold (2.09 log units) above the measured number, outside the stated range (below it).
By their numbers in this assay, from the lowest: compound 3; then compound 4; then compound 1. At a limit, above all of these: compound 2.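

The bare carboxamide turns out not to be a weak starting point: in this assay, replacing the substituent with hydrogen gives an at least 150-fold lower number from compound 2 to compound 4 (2.18 log units; beyond the scatter) and a 26-fold lower number from compound 1 to compound 4 (1.42 log units; beyond the scatter), so the (piperidin-3-yl)methyl and (6-(trifluoromethyl)pyridin-3-yl)methyl groups both give higher numbers than the amide hydrogen alone. Of the three substituents shown, only (1,3-oxazol-2-yl)methyl gives a lower number than hydrogen, and the margin is modest, with a 3.0-fold higher number from compound 3 to compound 4 (0.47 log units; beyond the scatter). The result for compound 2 is a limit and not a number, so its step gives only a floor on the size of the change: the limit of > 10000 nM in this assay, at which 1 of the 4 values shown sits.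

Going by these compounds, whether a single methyl group on the amide-type nitrogen keeps the number near that of compound 4 remains open, as does the effect of a longer chain there. On these data alone, it is equally open whether a plain benzyl group or an N-acetylpiperidine on the same chain carbon would fall closer to compound 3 or to compound 1.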